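Shortening the Acid Chain on the Chromone Amide

The compounds below may be only part of what the source reports. "The series", "measured", "known", "first", "only" and "open" are said of these compounds alone.

Measured so far:
compound 1 `O=C(Nc1nnn[nH]1)c1cc(=O)c2ccccc2o1` gives 100%
compound 2 `O=C(O)CCCCCNC(=O)c1cc(=O)c2ccccc2o1` gives 0%
compound 3 `Cn1nnnc1NC(=O)c1cc(=O)c2ccccc2o1` gives 0%

All three numbers come from a functional assay on the whole organism for inhibition, with Rattus norvegicus as the target, with a stated time of 30 min, at a dose of 1 mg/kg by the intravenous route; a higher number here means more inhibition at the dose given (going by the name of the read-out), a lower number less inhibition. Compound 3 stands at the bottom: it is level with compound 2 at the digits reported, the two together being the lowest of the three, and compound 1 sits far above both. Among the compounds with values here, the only measured step that touches compound 3 is the one from compound 1, where a methyl on an aromatic nitrogen in place of hydrogen gives a number 100 percentage points lower from compound 1 to compound 3 (beyond the scatter), a large fall in this assay.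

The next compound, compound 4 `O=C(O)CCNC(=O)c1cc(=O)c2ccccc2o1`, differs from compound 3 by 2-carboxyethyl in place of 1-methyl-1H-tetrazol-5-yl on an amide-type nitrogen. Within the data shown here, no measured step joins two compounds by exactly this change, so the large fall from compound 1 to compound 3 does not bear on it directly. What does bear on it is compound 2, whose amide nitrogen also carries a carboxyalkyl chain, a longer one, and which gives 0% in this assay. With the shared core held fixed and an acid chain again on the amide nitrogen, no rise beyond the scatter is expected, so the step is estimated as a number 5 percentage points higher from compound 3 to compound 4 (within the scatter). Compound 4 is therefore expected to give about 5%, within a range of 0% to 25%.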

Compound 4, a percentage reported as inhibition, in the whole organism at one dose (the size of the read-out at that dose, not a potency): 0%
Estimate against measurement, compound 4: 5 percentage points above, and the stated range covers the measured number.
By their numbers in this assay, from the lowest: compounds 2, 3 and 4 (each within the scatter of the next); then compound 1.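

In this assay the length of the acid chain on the amide-type nitrogen makes no visible difference here: carboxy in place of 3-carboxypropyl gives no change at the digits printed from compound 2 to compound 4 (within the scatter) at the single dose tested, so the shorter chain restores no inhibition. Replacing a ring with this chain also leaves the reading unmoved when the ring carries the methyl, since 2-carboxyethyl in place of 1-methyl-1H-tetrazol-5-yl gives no change at the digits printed from compound 3 to compound 4 (within the scatter) and the methylated ring and the acid chain cannot be told apart in this assay. Against the unmethylated ring the same chain gives a number 100 percentage points lower from compound 1 to compound 4 (beyond the scatter) and this makes 1H-tetrazol-5-yl, among the four groups compared on this nitrogen, the only one that gives a reading above the other three.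

From the compounds shown here alone, compounds 2, 3 and 4 all read the same, so this assay at this dose cannot separate them, and it remains open whether an amine on the chain or a triazole on the amide-type nitrogen would keep any of the inhibition seen with compound 1. No measurement at hand offers a reason for any of these steps.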